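The source may hold more compounds than are shown below. What is called first, only, known or untested is meant among the compounds shown, and "the series" means these compounds.

Measured compounds:

Compound 1, `Oc1cccc(-c2cc(-c3ccoc3)cc(-c3ccccc3O)n2)c1`: in a functional assay on HCT-15 cells (Homo sapiens) for cytotoxicity, read by CCK-8 assay (a lower number here means a stronger inhibitor, a higher number a weaker inhibitor), compound 1 gives > 50000 nM, which is a limit of the assay rather than a number.
Compound 2, `Oc1ccc(-c2cc(-c3ccoc3)cc(-c3ccccc3O)n2)cc1`: in this assay compound 2 gives > 50000 nM, again a limit of the assay.
Compound 3, `Oc1ccc(-c2cc(-c3ccccn3)cc(-c3cccc(O)c3)n2)cc1`: in this assay compound 3 gives > 50000 nM, once more a limit.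

Compound 1 and compound 2 differ in one place, by 4-hydroxyphenyl in place of 3-hydroxyphenyl on an aromatic carbon. The step that the two limits leave unreadable from compound 1 to compound 2 cannot be sized, because both ends sit at the limit of > 50000 nM in this assay, at which 3 of the 3 values shown sit. Compound 3 differs from compound 1 in more than one place, and the difference between the two cores is not broken down here.

Compound 4, `Oc1ccc(-c2cc(-c3ccccn3)cc(-c3ccc(O)cc3)n2)cc1`, has not yet been measured. It differs from compound 3 by 4-hydroxyphenyl in place of 3-hydroxyphenyl on an aromatic carbon. This is the same kind of change as that from compound 1 to compound 2, though the surroundings are not identical: in compound 1 the carbon that carries the change is meta to a 2-hydroxyphenyl group and meta to a furan-3-yl group, whereas in compound 3 it is meta to a 4-hydroxyphenyl group and meta to a pyridin-2-yl group.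

For compound 4 the step that the limit leaves unreadable from compound 3 to compound 4 is expected to be small, since this kind of change gave no readable step between compound 1 and compound 2, and because compound 3 already gives > 50000 nM. The chance that the assay again returns only a limit is therefore judged high. Compound 4 is expected to come in around 80000 nM, most plausibly between 30000 nM and 300000 nM.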

Compound 4, half-maximal inhibitory concentration: > 50000 nM
Compound 4: no number, only a limit; the forecaster's own chance of this, stated with the estimate: 85%; the middle value is on the limit's open side.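

In this assay compound 4 gives > 50000 nM, which is a limit of the assay and not a number. No step can be read between compound 3 and compound 4, because both sit at the same limit: the limit of > 50000 nM in this assay, at which 4 of the 4 values shown sit. The compounds shown leave open whether 4-hydroxyphenyl in place of 3-hydroxyphenyl changes the result in this assay at all, since none of them gives a measurable value there.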